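Amide aryl swap to nitrophenyl on a flavonol scaffold

The source may report more compounds than this note shows. Statements on the series, on what has been measured and on what is new or still open speak of the compounds shown alone.

Compound 1 `O=C(Nc1cccc(-c2oc3cc(-c4ccc(F)cc4)ccc3c(=O)c2O)c1)c1cccc(F)c1` gives 15500 nM in a functional assay on HepG2 cells (Homo sapiens) for antiproliferative activity, read by CCK-8 assay, with a stated time of 72 h; on this read-out higher numbers stand for weaker inhibition and lower numbers for stronger inhibition. Compound 2 `O=C(Nc1cccc(-c2oc3cc(-c4ccc(F)cc4)ccc3c(=O)c2O)c1)c1ccc(Br)cc1F` reaches only a limit of this assay, > 100000 nM. Compound 3 `Cc1cc(C)cc(C(=O)Nc2cccc(-c3oc4cc(-c5ccc(F)cc5)ccc4c(=O)c3O)c2)c1` gives 13400 nM.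

Among the two numbers given, compound 3 sits lowest, with compound 1 nearest, though that gap is within the scatter (a 1.2-fold lower number from compound 1 to compound 3 (0.06 log units; within the scatter)). Compound 4 `O=C(Nc1cccc(-c2oc3cc(-c4ccc(F)cc4)ccc3c(=O)c2O)c1)c1ccc([N+](=O)[O-])cc1` differs from compound 3 by 4-nitrophenyl in place of 3,5-dimethylphenyl on a carbonyl carbon. Of the steps at this same carbonyl carbon, one is flat (a 1.2-fold lower number from compound 1 to compound 3 (0.06 log units; within the scatter)) and the other large (an at least 7.4-fold lower number from compound 2 to compound 3 (0.87 log units; beyond the scatter)), so only compound 2 shows a clear loss there, reaching a limit (the limit of > 100000 nM in this assay, at which 1 of the 3 values shown sits). For compound 4 a modest weakening beyond the scatter is expected, a 1.9-fold higher number from compound 3 to compound 4 (0.27 log units; within the scatter). The estimate for compound 4 in this assay is 25000 nM, expected between 8000 nM and 80000 nM.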

Compound 4, half-maximal inhibitory concentration: 1860 nM
Estimate against measurement, compound 4: 13-fold (1.13 log units) above, and the stated range ends above it.
By their numbers in this assay, from the lowest: compound 4; then compounds 3 and 1 (each within the scatter of the next). At a limit, above all of these: compound 2.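

In this assay, among the compounds shown here, this carbonyl carbon proved able to gain as well as lose: the only clear step there so far had been a loss, whereas 4-nitrophenyl gives a 7.2-fold lower number from compound 3 to compound 4 (0.86 log units; beyond the scatter) and an 8.3-fold lower number from compound 1 to compound 4 (0.92 log units; beyond the scatter). A wider gap still is an at least 53-fold lower number from compound 2 to compound 4 (1.73 log units; beyond the scatter). That step is only a bound, as compound 2 stands at a limit: the limit of > 100000 nM in this assay, at which 1 of the 4 values shown sits.

As far as these compounds go, it remains open whether the gain depends on the nitro group itself, or would persist with a 4-aminophenyl or 4-cyanophenyl group on this carbonyl carbon.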